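Notes on the step from compound 2 to compound 3

The source may report more compounds than this note shows. Statements on the series, on what has been measured and on what is new or still open speak of the compounds shown alone.

- compound 1 `CC1(C)Oc2ccc(C#N)cc2[C@@H](/N=C(\NC#N)Sc2ccccc2)[C@@H]1O`: 4900 nM
- compound 2 `CC1(C)Oc2ccc(C#N)cc2[C@@H](/N=C(\NC#N)NCc2ccccc2)[C@@H]1O`: 2400 nM

Both compounds were measured in a functional assay (aorta) with Rattus norvegicus as the target; on this read-out higher numbers stand for weaker inhibition and lower numbers for stronger inhibition. Of the two, compound 2 has the lowest number at 2400 nM, and compound 1 is the nearest and only other point. The next structure is compound 3 `CC1(C)Oc2ccc(C#N)cc2[C@@H](/N=C(\NC#N)Nc2cccc(C(F)(F)F)c2)[C@@H]1O`, which has not yet been measured. The change is 3-(trifluoromethyl)phenyl in place of benzyl on an amine nitrogen, with 3-(trifluoromethyl)phenyl in place of benzyl on an amine nitrogen.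

Going by the values given here, only one measured step bears on this change, and only indirectly. That step is a 2.0-fold lower number from compound 1 to compound 2 (0.31 log units; beyond the scatter), a modest change just beyond the scatter, with benzylamino in place of phenylsulfanyl. Among the compounds with values here, no measured compound has an aromatic ring directly on the amine nitrogen or carries a trifluoromethyl group, so the direction is poorly supported. A modest move to a lower number in this assay is tentatively expected, with a wide range. The expected change is a 2.0-fold lower number from compound 2 to compound 3 (0.30 log units; within the scatter). For compound 3 the estimated value is 1200 nM, with an expected range of 300 nM to 5000 nM.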

Compound 3, half-maximal inhibitory concentration: 1600 nM
Compound 3: middle estimate off by 1.3-fold (0.12 log units), on the low side; the measured number falls inside the stated range.
By their numbers in this assay, from the lowest: compounds 3 and 2 (each within the scatter of the next); then compound 1.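

In this assay, putting 3-(trifluoromethyl)phenyl in place of benzyl on the amine nitrogen gives a 1.5-fold lower number from compound 2 to compound 3 (0.18 log units; within the scatter), so this read-out does not separate the two compounds. Until now, the only aromatic ring on this amine nitrogen was held through the benzyl carbon; compound 3 shows that a ring attached directly to the nitrogen, and bearing trifluoromethyl, is compatible with a value in the same range as compound 2. No measurement available here offers an explanation for this result.

The compounds shown leave open whether direct attachment of the ring and the trifluoromethyl group each matter on their own, as an unsubstituted phenyl on the amine nitrogen, or a chlorine or methoxy group in place of trifluoromethyl on the ring, would be needed to pull the two apart. Also open, going by these compounds, is how a longer chain such as phenethyl on the same nitrogen, or a small alkyl group such as cyclopentyl with no ring of aromatic carbon, would read in this assay.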